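Swapping Dichlorophenyl for Bromophenyl on the Chain Carbon

The source may hold more compounds than are shown below. What is called first, only, known or untested is meant among the compounds shown, and "the series" means these compounds.

Measured compounds:
compound 1 `O=C(/C(=C\c1ccc(O)c([N+](=O)[O-])c1)SCc1ccc(Br)cc1)c1ccc(Br)cc1`: 10000 nM
compound 2 `O=C(/C(=C\c1ccc(O)c([N+](=O)[O-])c1)SCc1ccc(Br)cc1)c1ccc(Cl)cc1Cl`: 10000 nM
compound 3 `COc1ccc(S/C(=C/c2ccc(Cl)cc2Cl)C(=O)c2ccc(Br)cc2)cc1`: 1000 nM

Three compounds were measured in a functional assay on DU-145 cells (Homo sapiens) for inhibition, read by trypan blue exclusion, with a stated time of 96 h; a higher number here means a weaker inhibitor of growth, a lower number a stronger inhibitor of growth. Compound 1 and compound 2 share one core, while compound 3 is built on another; the difference between the two cores is not broken down here. Between compound 2 and compound 1 the step is no change at the digits printed from compound 2 to compound 1 (within the scatter), the change being (4-bromophenyl in place of 2,4-dichlorophenyl on a carbonyl carbon). Compound 3 stands lowest of the three, and its gap to compound 1 and to compound 2 lies beyond the scatter.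

Compound 4 `COc1ccc(S/C(=C/c2ccc(Br)cc2)C(=O)c2ccc(Br)cc2)cc1` has not yet been measured in this assay. It differs from compound 3 by 4-bromophenyl in place of 2,4-dichlorophenyl on a double-bonded chain carbon bound to a double-bonded chain carbon. This is the same kind of change as that from compound 2 to compound 1, not the same: there the place was a carbonyl carbon whose other neighbours are a double-bonded chain carbon, here it is a double-bonded chain carbon bound to a double-bonded chain carbon. Resting on no change at the digits printed from compound 2 to compound 1 (within the scatter), which showed no movement within the scatter, the step from compound 3 to compound 4 is expected to be no change at the digits printed from compound 3 to compound 4 (within the scatter). Compound 4 is therefore estimated at 1000 nM in this assay, within a range from 400 nM to 3000 nM.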

Compound 4, concentration for 50% growth inhibition: 20000 nM
Beside the measured number, compound 4's estimate is 20-fold (1.30 log units) below it; the measured number lies above the stated range.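

In this assay, putting 4-bromophenyl in place of 2,4-dichlorophenyl on a double-bonded chain carbon bound to a double-bonded chain carbon gives a 20-fold higher number from compound 3 to compound 4 (1.30 log units; beyond the scatter), a large loss of growth inhibition. The change therefore did not carry over unchanged from the core of compound 1 and compound 2 to the core of compound 3, and the two steps differ: the same change on two cores in this assay, no change at the digits printed (within the scatter) from compound 2 to compound 1 and a 20-fold higher number (1.30 log units; beyond the scatter) from compound 3 to compound 4, 20-fold (1.30 log units) apart, beyond the scatter of two such steps This does not show why they differ, since the two pairs differ both in core and in the place of the change, and a single pair on each core cannot show which result is more typical of the series.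

The compounds shown leave open how the core of compound 3 responds to this change on the carbonyl carbon, and how the core of compound 1 responds to it on the double-bonded chain carbon. They also leave open how a phenyl ring carrying an amine or a carboxylic acid would behave in this assay at either place.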